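This account rests on a few compounds, and the source may have more. Where it says the series, first, only, none or still open, it means among the compounds named here.

Working notes on the coumarin amide series.

Compound 1 `CC(C)=CCc1cc(C(=O)Nc2cc3ccc(OCC4CCN(C)C4)c(C)c3oc2=O)ccc1O` is the reference point. Among the compounds with values here, in a functional assay on SK-BR-3 cells (Homo sapiens) for antiproliferative activity (a lower number here means a stronger inhibitor, a higher number a weaker inhibitor), compound 1 gives 920 nM, the higher of the two numbers so far. Compound 2 `CC(C)=CCc1cc(C(=O)Nc2cc3ccc(OCCCNCCO)c(C)c3oc2=O)ccc1O` gives 610 nM; the step of a 1.5-fold lower number from compound 1 to compound 2 (0.18 log units; within the scatter) is within the scatter, so the two stand level. Compound 3 `CC(C)=CCc1cc(C(=O)Nc2cc3ccc(OCCCN(C)c4ccccc4)c(C)c3oc2=O)ccc1O` gives only a limit, > 50000 nM, and its number is not known; the limit of > 50000 nM in this assay, at which 1 of the 3 values shown sits, marks where it sits.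

The step to compound 4 `CC(C)=CCc1cc(C(=O)Nc2cc3ccc(OCCCN[C@H](C)c4ccccc4)c(C)c3oc2=O)ccc1O` is 2-((1-phenylethyl)amino)ethyl in place of 1-methylpyrrolidin-3-yl on a saturated chain carbon bound to an oxygen on an aromatic ring. Within the data shown here, two measured steps bear on it. The step of an at least 54-fold higher number from compound 1 to compound 3 (1.73 log units; beyond the scatter) and the step of an at least 81-fold higher number from compound 2 to compound 3 (1.91 log units; beyond the scatter) both show that placing methyl(phenyl)amino on the chain destroys activity. Compound 4 keeps a phenyl ring on the chain, but attached through 2-((1-phenylethyl)amino)ethyl, which carries one hydrogen-bond donor as (2-hydroxyethyl)amino in compound 2 does, rather than the donor-free methyl(phenyl)amino of compound 3. The expectation for compound 4 is therefore a number nearer to compound 2 than to compound 3, with a moderate loss against compound 1 allowed for the added phenyl.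

Estimated step: a 1.6-fold higher number from compound 1 to compound 4 (0.21 log units; within the scatter). Compound 4 is estimated at 1500 nM, with a range from 400 nM to 8000 nM.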

Compound 4, half-maximal inhibitory concentration: 1000 nM
The estimate for compound 4 lay 1.5-fold (0.18 log units) above the measured number, and the stated range covers the measured number.
By their numbers in this assay, from the lowest: compounds 2, 1 and 4 (each within the scatter of the next). At a limit, above all of these: compound 3.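

Within the data shown here, the position tolerates a much larger group than the earlier compounds showed: with the step of a 1.1-fold higher number from compound 1 to compound 4 (0.04 log units; within the scatter) and the step of a 1.6-fold higher number from compound 2 to compound 4 (0.21 log units; within the scatter), a phenyl ring on the chain costs nothing that can be read in this assay, and 1-phenylethyl stands level with 2-hydroxyethyl on the amine nitrogen. The step of an at least 50-fold lower number from compound 3 to compound 4 (1.69 log units; beyond the scatter) shows that the loss at compound 3 does not follow from a phenyl ring on the chain as such, but goes with methyl(phenyl)amino as against (1-phenylethyl)amino. The value for compound 3 remains a limit of the assay, not a number, so the true size of that step is unknown: the limit of > 50000 nM in this assay, at which 1 of the 4 values shown sits.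

The compounds shown do not separate the two differences between compound 3 and compound 4, the methyl on the amine nitrogen and the carbon link to the phenyl ring; a plain phenylamino group and a methyl on the amine nitrogen of compound 4 would bear on this. Also open, on these data alone, are the mirror-image 1-phenylethyl group, a benzyl group on the same nitrogen, and a longer chain between the oxygen and the amine.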